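Swapping trifluoromethyl for methyl on the benzyl sulfide

The compounds below may be only part of what the source reports. "The series", "measured", "known", "first", "only" and "open" are said of these compounds alone.

Of the compounds shown here, three of one series have been measured in an ADME assay on microsomes from liver (Homo sapiens) for metabolic stability, read by LC-MS, using NADPH, tested at 5 uM; on this read-out higher numbers stand for a longer-lived compound and lower numbers for a shorter-lived compound. Compound 1 `Cc1cc(S(=O)(=O)/N=C(\N)n2nccc2-c2ccccc2)c(SCc2ccc(Cl)cc2)cc1Cl` gives 0.34 h, compound 3 `Cc1cc(S(=O)(=O)/N=C(\N)n2nccc2-c2ccccc2)c(SCc2ccc(C(F)(F)F)cc2)cc1Cl` gives 0.176 h, and compound 2 `Cc1cc(-c2ccccc2)n(/C(N)=N/S(=O)(=O)c2cc(C)c(Cl)cc2SCc2ccc(C(F)(F)F)cc2)n1` gives 0.241 h, which stands second of the three numbers and within the scatter of both others. Compound 4 `Cc1ccc(CSc2cc(Cl)c(C)cc2S(=O)(=O)/N=C(\N)n2nc(C)cc2-c2ccccc2)cc1` differs from compound 2 by methyl in place of trifluoromethyl on an aromatic carbon. The measured step that comes nearest to this change is a 1.9-fold lower number from compound 1 to compound 3 (0.29 log units; within the scatter), at the same position on the benzyl ring, while a 1.4-fold lower number from compound 2 to compound 3 (0.14 log units; within the scatter) concerns another position. Neither step has moved the read-out beyond the scatter, so only a small shift, if anything toward a longer-lived compound, is expected. Compound 4 is therefore estimated at 0.35 h, with a range from 0.17 h to 0.7 h. The expected step is a 1.5-fold higher number from compound 2 to compound 4 (0.16 log units; within the scatter).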

Compound 4, half-life: 0.176 h
Estimate against measurement, compound 4: 2.0-fold (0.30 log units) above, within the range that was stated.
By their numbers in this assay, from the lowest: compounds 3, 4, 2 and 1 (each within the scatter of the next).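

At this position on the benzyl ring, the change from 4-(trifluoromethyl)benzyl to 4-methylbenzyl gives a 1.4-fold lower number from compound 2 to compound 4 (0.14 log units; within the scatter) and so does not separate the two groups by half-life. Alongside a 1.9-fold lower number from compound 1 to compound 3 (0.29 log units; within the scatter) at the same place, the methyl, chloro and trifluoromethyl steps all stay within the scatter, so neither step shows this position moving the half-life. Nothing measured here gives a reason for either step. From the compounds shown here alone, it remains open whether an amine, a carboxylic acid or a longer chain at this place would move the half-life beyond the scatter. The same holds for changes elsewhere on the core.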